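A few compounds are considered here, and "the series" means these few. Any claim that something is new, unique, unknown or untested is made for them only; others in the source may bear on it.

Measured compounds:
compound 1, `c1ccc(-c2cn3ccnc3c(-c3ccc4ncn(C5CCCCC5)c4c3)n2)cc1`, 1.74
compound 2, `O=Cc1ccc(-c2cn3ccnc3c(-c3ccc4ncn(C5CCCCC5)c4c3)n2)cc1`, 1.5
compound 3, `CC(=O)c1ccc(-c2cn3ccnc3c(-c3ccc4ncn(C5CCCCC5)c4c3)n2)cc1`, 2.06

In a physicochemical assay for lipophilicity, using the shake flask method, in phosphate buffer, measured as octanol-water partition, with a stated time of 85 min, at pH 7.4 (a higher number here means a more lipophilic compound, a lower number a more polar compound), compound 2 stands lowest of the three numbers. Among the compounds with values here, the steps that bear on the next change are a number 0.24 log units lower from compound 1 to compound 2 (within the scatter) and a number 0.56 log units higher from compound 2 to compound 3 (beyond the scatter); the first of these lies within the scatter, the second beyond it. Compound 4 `Clc1ccc(-c2cn3ccnc3c(-c3ccc4ncn(C5CCCCC5)c4c3)n2)cc1` differs from compound 2 in one place: chloro in place of formyl on an aromatic carbon. Taking the formyl away would roughly reverse a number 0.24 log units lower from compound 1 to compound 2 (within the scatter); no measured step shows chloro entering in place of hydrogen on this ring, so that part of the change rests on no number here. Compound 4 is therefore expected to run higher than compound 2, by a number 0.90 log units higher from compound 2 to compound 4 (beyond the scatter), beyond the scatter. The estimate for compound 4 is 2.4, with a range from 2 to 2.8.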

Compound 4, partition coefficient: 1.51
Beside the measured number, compound 4's estimate is 0.89 log units above it; the measured number lies below the stated range.
By their numbers in this assay, from the lowest: compounds 2, 4 and 1 (each within the scatter of the next); then compound 3.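

At this aromatic carbon, in this assay, chloro cannot be told apart from formyl, a number 0.01 log units higher from compound 2 to compound 4 (within the scatter), or from hydrogen, a number 0.23 log units lower from compound 1 to compound 4 (within the scatter). Acetyl alone stands apart from chloro, a number 0.55 log units lower from compound 3 to compound 4 (beyond the scatter), so compound 3 is the only one of the four separated from the others. Nothing available here explains this result.

From the compounds shown here alone, it remains open whether an amine, a carboxylic acid or a methoxy group at this place would stay with compound 1, compound 2 and compound 4 or separate as acetyl does. Going by these compounds, whether bromo or fluoro would read like chloro is also open.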